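A Carboxyethyl Group on the Amide Nitrogen of Compound 1

The compounds below may be only part of what the source reports. "The series", "measured", "known", "first", "only" and "open" are said of these compounds alone.

Compound 1 `CCCNC(=O)Cn1nc(N)c2c(C(F)(F)F)cc(-c3ccccc3)nc21` gives 15500 nM in a functional assay on DU-145 cells (Homo sapiens) for cytotoxicity, read by MTT assay, with a stated time of 24 h (a higher number here means a weaker inhibitor, a lower number a stronger inhibitor), the second highest of three measured numbers. Compound 3 `CN1CCN(C(=O)Cn2nc(N)c3c(C(F)(F)F)cc(-c4ccccc4)nc32)CC1` gives 18100 nM, and the step of a 1.2-fold higher number from compound 1 to compound 3 (0.07 log units; within the scatter) stays within the scatter, while compound 2 `Nc1nn(CC(=O)NC2CCCCC2)c2nc(-c3ccccc3)cc(C(F)(F)F)c12` gives 3100 nM, the step of a 5.0-fold lower number from compound 1 to compound 2 (0.70 log units; beyond the scatter) being the only one beyond the scatter at this position. Compound 4 `CC(NC(=O)Cn1nc(N)c2c(C(F)(F)F)cc(-c3ccccc3)nc21)C(=O)O` differs from compound 1 by 1-carboxyethyl in place of propyl on an amide-type nitrogen. Within the data shown here, the two measured steps at this amide-type nitrogen show that a cyclohexyl gains modestly and a 4-methylpiperazin-1-yl changes nothing; no measured step introduces a carboxylic acid, so no gain is expected here. The expected step is a 1.6-fold higher number from compound 1 to compound 4 (0.21 log units; within the scatter), a small move towards a weaker inhibitor. Compound 4 is therefore estimated at 25000 nM, in the range 10000 nM to 70000 nM.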

Compound 4, half-maximal inhibitory concentration: 22400 nM
Beside the measured number, compound 4's estimate is 1.1-fold (0.05 log units) above it; the range from low to high includes it.
By their numbers in this assay, from the lowest: compound 2; then compounds 1, 3 and 4 (each within the scatter of the next).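

In this assay, 1-carboxyethyl on the amide-type nitrogen reads the same as propyl (a 1.4-fold higher number from compound 1 to compound 4 (0.16 log units; within the scatter)), and (1-carboxyethyl)amino on the carbonyl carbon reads the same as 4-methylpiperazin-1-yl (a 1.2-fold higher number from compound 3 to compound 4 (0.09 log units; within the scatter)). Three different groups now sit together at this position, and compound 2 with its cyclohexyl alone stands apart, also from the new acid-bearing chain (a 7.2-fold higher number from compound 2 to compound 4 (0.86 log units; beyond the scatter)). Nothing available explains why cyclohexyl alone differs. On these data alone, whether a phenyl ring or a longer chain such as butyl would follow cyclohexyl stays open, as does whether an amine or a methyl ester would read like 1-carboxyethyl.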